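Notes on a side chain change at the carbonyl

This account rests on a few compounds, and the source may have more. Where it says the series, first, only, none or still open, it means among the compounds named here.

Values so far in an ADME assay on HepG2 2.2.15 cells (Homo sapiens) for cytotoxicity; a higher number here means that more compound is tolerated, a lower number that less compound is tolerated:
- compound 1 (`CCC(=O)OCCc1c(-c2ccccc2Cl)c2cc(Cl)ccc2[nH]c1=O`): 95000 nM
- compound 2 (`O=C(CCOc1ccccc1)OCCc1c(-c2ccccc2Cl)c2cc(Cl)ccc2[nH]c1=O`): 46000 nM

Going by the values given here, compound 2 at 46000 nM holds the lower of the two numbers, and compound 1 at 95000 nM is its only neighbour. Compound 3 (`COc1ccc(/C=C/C(=O)OCCc2c(-c3ccccc3Cl)c3cc(Cl)ccc3[nH]c2=O)cc1`) differs from compound 2 in one group (2-(4-methoxyphenyl)ethenyl in place of 2-phenoxyethyl on a carbonyl carbon), with 2-(4-methoxyphenyl)ethenyl in place of 2-phenoxyethyl on a carbonyl carbon.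

Among the compounds with values here, only one measured step bears on this change. It is modest (a 2.1-fold lower number from compound 1 to compound 2 (0.31 log units; beyond the scatter)) and comes with phenoxy in place of hydrogen on a saturated chain carbon. That step adds a group, whereas the change to compound 3 exchanges one group for another, and each of these groups holds one six-membered aromatic ring of carbon only. Within the data shown here, no measured pair tests this exchange directly, so the expectation is loose. In this assay no step beyond the scatter is expected. The estimated step is small (a 1.0-fold lower number from compound 2 to compound 3 (0.01 log units; within the scatter)) and is expected to stay within the scatter. For compound 3 the expected value is 45000 nM with an estimated range from 20000 nM to 95000 nM for now.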

Compound 3, half-maximal cytotoxic concentration: > 1200000 nM
Compound 3 gave a limit, no number (the forecaster's own chance of this, stated with the estimate: 15%); middle value at least 26-fold (1.42 log units) from the limit.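

The group on the carbonyl carbon matters far more in this assay than the first pair suggested: the exchange of 2-phenoxyethyl for 2-(4-methoxyphenyl)ethenyl gives an at least 26-fold higher number from compound 2 to compound 3 (1.41 log units; beyond the scatter), whereas phenoxy on the saturated chain gave only a 2.1-fold lower number from compound 1 to compound 2 (0.31 log units; beyond the scatter). An aromatic ring at this position does not by itself lower the number, as both groups hold one six-membered aromatic ring of carbon only, yet replacing ethyl with 2-(4-methoxyphenyl)ethenyl gives an at least 12-fold higher number from compound 1 to compound 3 (1.10 log units; beyond the scatter), the opposite direction to the phenoxy step. Compound 3 gives > 1200000 nM, which is a limit of the assay and not a number: the limit of > 1200000 nM in this assay, at which 1 of the 3 values shown sits.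

The compounds shown do not separate the contribution of the methoxy group from that of the double bond outside the aromatic ring, so 2-phenylethenyl or a saturated 2-(4-methoxyphenyl)ethyl group on the same carbonyl carbon would be the informative comparison. From the compounds shown here alone, it also remains open whether an amine or a carboxylic acid at the end of a longer chain on this carbonyl carbon would keep the number near that of compound 1 or shift it towards the limit of compound 3.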